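The compounds below may be only part of what the source reports. "The series", "measured", "known", "first", "only" and "open" are said of these compounds alone.

Compound 1 `COc1ccc(C2N=C(SCc3ccc(Cl)cc3)NC(C)=C2C(=O)Nc2ccc(Br)cc2)cc1`: 16.5%
Compound 2 `CC1=C(C(=O)Nc2ccc([N+](=O)[O-])cc2)C(c2ccc(Br)cc2)N=C(SCc2ccccc2)N1`: 13.4%

In a functional assay on the whole organism (artery, strain albino) with Rattus norvegicus as the target, with a stated time of 120 min, at a dose of 10 mg/kg by the oral route (a lower number here means less inhibition, a higher number more inhibition at the dose given (going by the name of the read-out)), compound 2 gives the lower of the two numbers, yet compound 1 stands only a small gap away, within the scatter of repeated measurements. Compound 3 `CC1=C(C(=O)Nc2ccc([N+](=O)[O-])cc2)C(c2ccc(Br)cc2)N=C(SCc2ccccc2Cl)N1` differs from compound 2 by a single change: chloro in place of hydrogen on an aromatic carbon. Among the compounds with values here, no step between measured compounds differing in one place is available to guide the prediction, so the expected step of a number 0.6 percentage points higher from compound 2 to compound 3 (within the scatter) is none beyond the scatter, in neither direction. Compound 3 is therefore estimated at 14%, with a range from 3% to 26%.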

Compound 3, a percentage reported as inhibition, in the whole organism at one dose (the size of the read-out at that dose, not a potency): 7.7%
Beside the measured number, compound 3's estimate is 6.3 percentage points above it, and the stated range covers the measured number.
By their numbers in this assay, from the lowest: compounds 3, 2 and 1 (each within the scatter of the next).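

In this assay, putting chloro in place of hydrogen on an aromatic carbon, ortho to a large group, gives a number 5.7 percentage points lower from compound 2 to compound 3 (within the scatter). Within the data shown here, this is the first single-place reading: going from benzylsulfanyl to (2-chlorobenzyl)sulfanyl does not move the read-out beyond the scatter at this dose. Nothing measured bears on the cause of this small step.

As far as these compounds go, whether an amine or a carboxylic acid on this same aromatic carbon would shift the number beyond the scatter stays open. So does whether a longer chain in place of the benzyl group would do so.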